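The compounds below may be only part of what the source reports. "The series", "measured", "known", "first", "only" and "open" are said of these compounds alone.

Among the measured compounds shown here, compound 1 `Cc1ccc(S(=O)(=O)n2cnc3c(Cl)ncnc32)cc1` is one of two compounds measured in a functional assay on Huh-7 cells (Homo sapiens) for cytotoxicity, read by sulforhodamine B assay, with a stated time of 72 h; on this read-out lower numbers stand for stronger inhibition and higher numbers for weaker inhibition. In this assay compound 1 gives 20800 nM. The other, compound 2 `C1=CC(CCNc2ncnc3[nH]cnc23)CCC1`, gives in this assay 14200 nM, a number within the scatter of that of compound 1, so the two cannot be told apart. Compound 3 `Cc1ccc(S(=O)(=O)n2cnc3c(N4CCC(C)CC4)ncnc32)cc1` has not yet been measured; it differs from compound 1 by 4-methylpiperidin-1-yl in place of chloro on an aromatic carbon. For the measured compounds named here, no measured pair shows the effect of this change, so no step in this assay clearly beyond the scatter is expected. The estimated step is a 1.2-fold higher number from compound 1 to compound 3 (0.08 log units; within the scatter). Compound 3 is expected to give 25000 nM, within 8000 nM to 80000 nM.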

Compound 3, half-maximal inhibitory concentration: 17800 nM
Beside the measured number, compound 3's estimate is 1.4-fold (0.15 log units) above it, and the stated range covers the measured number.
By their numbers in this assay, from the lowest: compounds 2, 3 and 1 (each within the scatter of the next).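

Placing 4-methylpiperidin-1-yl in place of chloro on this aromatic carbon gives a 1.2-fold lower number from compound 1 to compound 3 (0.07 log units; within the scatter) in this assay. Among the compounds shown here, this is the first measured pair at this position, and it shows that a ring-bearing group of 7 heavy atoms can replace the single chlorine with no change that can be told from the scatter. Nothing available explains this result.

On these data alone, what a morpholin-4-yl or an open-chain amine would give at this carbon remains open. So does whether piperidin-1-yl without its methyl would read the same.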